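This account rests on a few compounds, and the source may have more. Where it says the series, first, only, none or still open, it means among the compounds named here.

Measured compounds in a functional assay on ECa-109 cells for inhibition, with ECa-109 cell line (Homo sapiens) as the target, read by sulforhodamine B assay; on this read-out higher numbers stand for weaker inhibition and lower numbers for stronger inhibition:
- compound 1 `O=C1C(N2CCCCC2)=CC(=O)c2c1nc1n2[C@H]2OC[C@@H](O)[C@H]2OC1`: compound 1 gives > 8000 nM, which is a limit of the assay, not a number.
- compound 2 `COc1ccccc1NC1=CC(=O)c2nc3n(c2C1=O)[C@H]1OC[C@@H](O)[C@H]1OC3`: compound 2 gives > 4000 nM, again a limit rather than a number.
- compound 3 `O=C1C(N2CCC2)=CC(=O)c2c1nc1n2[C@H]2OC[C@@H](O)[C@H]2OC1`: compound 3 gives > 16000 nM, also a limit.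

Every value shown is thus a limit: the limit of > 16000 nM in this assay, at which 1 of the 3 values shown sits, the limit of > 4000 nM in this assay, at which 1 of the 3 values shown sits, and (the limit of > 8000 nM in this assay, at which 1 of the 3 values shown sits). Compound 2 stands at one of these limits, and the two other values are limits as well, so no ordering among the three can be read. For the measured compounds named here, the only step between measured compounds that differ in one place is a step that the two limits leave unreadable from compound 1 to compound 3; with a limit at each end its size is not readable, and it concerns azetidin-1-yl in place of piperidin-1-yl on a double-bonded ring carbon, not the amine nitrogen.

Compound 4 `O=C1C=C(Nc2cccc(Cl)c2)C(=O)c2c1nc1n2[C@H]2OC[C@@H](O)[C@H]2OC1` differs from compound 2 by 3-chlorophenyl in place of 2-methoxyphenyl on an amine nitrogen. Going by the values given here, no measured step touches the amine nitrogen, so nothing here points to a change beyond the scatter in either direction; the step that the limit leaves unreadable from compound 2 to compound 4 is expected to be small or not readable. For compound 4 the estimate is 8000 nM, with a range from 2000 nM to 30000 nM, and most likely the assay will again report only a limit.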

Compound 4, half-maximal inhibitory concentration: 4690 nM
Compound 4: middle estimate off by 1.7-fold (0.23 log units), on the high side; the measured number falls inside the stated range.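

On these data alone, no size can be read for the step from compound 2 to compound 4: compound 2 gives only a limit of the assay, not a number, and the effect of 3-chlorophenyl in place of 2-methoxyphenyl on the amine nitrogen stays unknown. The compounds shown leave open whether changing the group on that nitrogen alters inhibition, and by how much.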